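The source may hold more compounds than are shown below. What is called first, only, known or untested is meant among the compounds shown, and "the series" means these compounds.

Compound 1 `C[C@@H](NC(=O)Nc1ccc2c(Cl)c(OCCSC(=N)N)oc(=O)c2c1)c1ccccc1` gives 1.03 h
Compound 2 `N=C(N)SCCOc1oc(=O)c2cc(NC(=O)NC(c3ccccc3)c3ccccc3)ccc2c1Cl` gives 2.8 h
Compound 3 `N=C(N)SCCCOc1oc(=O)c2cc(NC(=O)NCc3ccccc3)ccc2c1Cl` gives 2.47 h

In an ADME assay for pharmacokinetics (on this read-out higher numbers stand for a longer-lived compound and lower numbers for a shorter-lived compound), compound 3 (2.47 h) lies within the usual scatter of compound 2 (2.8 h). Compound 1 (1.03 h) gives a lower number than compound 3, and that gap lies beyond the scatter.

The next molecule, compound 4 `N=C(N)SCCCOc1oc(=O)c2cc(NC(=O)Nc3ccccc3)ccc2c1Cl`, has phenyl in place of benzyl on an amide-type nitrogen. Among the measured compounds shown here, no two measured compounds differ in one place only, so no measured step guides this change. The expected outcome is no shift beyond the scatter, with an estimated step of a 1.1-fold lower number from compound 3 to compound 4 (0.05 log units; within the scatter) in this measurement.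

Compound 4 is expected to give about 2.2 h, within an estimated range of 1 h to 4.5 h.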

Compound 4, half-life: 2.47 h
Compound 4: middle estimate off by 1.1-fold (0.05 log units), on the low side; measured number inside the range.
By their numbers in this assay, from the lowest: compound 1; then compounds 3, 4 and 2 (each within the scatter of the next).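

Swapping benzyl for phenyl on the amide-type nitrogen gives the first one-place comparison in this assay, and it shows no shift (no change at the digits printed from compound 3 to compound 4 (within the scatter)). At this position, then, the read-out does not separate these two groups. No measured information offers a reason for this.

From the compounds shown here alone, it remains open whether a longer chain such as phenethyl, or a group bearing an amine or a carboxylic acid, would also leave the number within the scatter on this nitrogen. Going by these compounds, whether benzyl and phenyl would also match on a different side chain is equally open.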